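The source may hold more compounds than are shown below. What is called first, only, known or untested is meant among the compounds shown, and "the series" means these compounds.

Measured so far:
- compound 1 `COc1ccc(-c2nc3sc(-c4ccccc4)cn3n2)cc1`: 65%
- compound 2 `Clc1ccc(-c2cn3nc(-c4ccccc4)nc3s2)cc1`: 74%

Not yet measured:
- compound 3 `COc1ccc(-c2nc3sc(-c4ccc(Cl)cc4)cn3n2)cc1`

In a functional assay on T47D cells (Homo sapiens) for inhibition, read by sulforhodamine B assay, with a stated time of 48 h, tested at 10 uM (on this read-out lower numbers stand for less inhibition of growth and higher numbers for more inhibition of growth at the one concentration tested), compound 2 gives 74%. Within the data shown here, that value lies within the usual scatter of compound 1 at 65%, so compound 2 does not stand apart from the only other number available.

The step to follow is from compound 2 to compound 3: methoxy in place of hydrogen on an aromatic carbon. This places methoxy in place of hydrogen on an aromatic carbon, para to a large group. Compound 3 thus carries the methoxy group seen in compound 1 together with the chlorine seen in compound 2.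

Among the measured compounds shown here, no measured pair differs in one place only, so the data give no direct measure of this change. The expectation rests on compound 1 at 65% and compound 2 at 74%, which give no sign of a large separation. The expected a number 3 percentage points lower from compound 2 to compound 3 (within the scatter) is no change beyond the scatter, with no firm direction.

For compound 3 the estimated value in this assay is 71%, with an expected range from 56% to 85%.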

Compound 3, percent growth inhibition at one concentration: 45.1%
Compound 3: the middle estimate sits 25.9 percentage points above what was measured, outside the stated range (below it).
By their numbers in this assay, from the lowest: compound 3; then compounds 1 and 2 (each within the scatter of the next).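

In this assay, the two single-place changes point the same way: methoxy in place of hydrogen on an aromatic carbon, para to a large group, gives a number 28.9 percentage points lower from compound 2 to compound 3 (beyond the scatter) and chloro in place of hydrogen on an aromatic carbon gives a number 19.9 percentage points lower from compound 1 to compound 3 (beyond the scatter) in this series. Each group, when added to a compound already carrying the other, therefore lowers the number beyond the scatter, so among these three compounds the methoxy and chloro groups together give less growth inhibition than either of the compounds with one of them alone. Nothing at hand bears on the reason for either step.

The compounds shown leave open whether this drop is specific to methoxy, or whether a hydroxyl group, a longer ethoxy chain or an amine at the same place would lower the number to a similar extent when the chlorine is kept. They also leave open whether fluoro or a carboxylic acid in place of the chlorine would give the same result alongside methoxy, and how any of these changes would look beyond the one concentration tested.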